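Replacing the butyl(methyl)amino group of compound 1 with a ring ether

The source may report more compounds than this note shows. Statements on the series, on what has been measured and on what is new or still open speak of the compounds shown alone.

Compound 1 `CCCCN(C)c1nc(C(F)(F)F)ccc1CNC(=O)C(C)c1ccc(NS(C)(=O)=O)c(F)c1` is the reference of this small set. Going by the values given here, in a functional assay on CHO-K1 cells for antagonist activity at transient receptor potential cation channel subfamily V member 1 (Homo sapiens), read by FLIPR (on this read-out lower numbers stand for stronger inhibition and higher numbers for weaker inhibition), compound 1 gives 0.8 nM, the lowest of the three numbers measured so far. Compound 2 `C[C@H](C(=O)NCc1ccc(C(F)(F)F)nc1N1CC[C@@H](OCc2ccccc2)C1)c1ccc(NS(C)(=O)=O)c(F)c1` gives 1.4 nM, which lies within the scatter of compound 1. Compound 3 `C[C@H](C(=O)NCc1ccc(C(F)(F)F)nc1N1CC[C@H](N(C)C)C1)c1ccc(NS(C)(=O)=O)c(F)c1` gives 103 nM, a gap to compound 1 that is well beyond the scatter. Among the compounds with values here, no two of these measured compounds differ in one place only, so no single-change step is known.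

Compound 4 `CCCCOC1CCN(c2nc(C(F)(F)F)ccc2CNC(=O)C(C)c2ccc(NS(C)(=O)=O)c(F)c2)CC1` has not been measured. Against compound 1 the change is a group of 11 heavy atoms (9 carbon, 1 nitrogen, 1 oxygen; one six-membered non-aromatic ring with 1 hetero atom) in place of a group of 6 heavy atoms (5 carbon, 1 nitrogen; no ring), on an aromatic carbon. The group that leaves is an open chain; the group that enters contains one six-membered non-aromatic ring with one hetero atom and carries two hydrogen-bond acceptors where the old group carried one.

Compound 2 shows that a ring-bearing group at this position can keep the number near that of compound 1, while compound 3 shows that another ring-bearing group can raise it far. Within the data shown here, for compound 4 the expected step is a 3.1-fold higher number from compound 1 to compound 4 (0.49 log units; beyond the scatter), a modest move toward weaker inhibition, since no close precedent fixes it. The estimate for compound 4 in this assay is 2.5 nM, with a range from 0.7 nM to 10 nM.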

Compound 4, inhibition constant: 3.5 nM
Beside the measured number, compound 4's estimate is 1.4-fold (0.15 log units) below it; the range from low to high includes it.
By their numbers in this assay, from the lowest: compounds 1 and 2 (each within the scatter of the next); then compound 4; then compound 3.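

Going by these compounds alone, the step from the open chain to the ring-bearing group is the first single-change reading at this position: in this assay it is a 4.4-fold higher number from compound 1 to compound 4 (0.64 log units; beyond the scatter), and compound 4 still gives 3.5 nM. The aromatic carbon next to the ring nitrogen therefore accepts a group of 11 heavy atoms, with a six-membered non-aromatic ring and an added hydrogen-bond acceptor, at the cost of a modest step that lies beyond the scatter. No supporting measurement accounts for the size or direction of this step.

The change alters the ring, the oxygen and the size of the group at once, so the compounds shown cannot assign the step to any one of these features. On these data alone, it also remains open how this position would respond if the same ring carried a hydroxyl group, a primary amine or a carboxylic acid in place of its ether chain, or if the open butyl(methyl)amino group were replaced by a longer chain.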